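A few compounds are considered here, and "the series" means these few. Any claim that something is new, unique, unknown or untested is made for them only; others in the source may bear on it.

Measured compounds in a functional assay on NCI-H23 cells (Homo sapiens) for cytotoxicity, read by sulforhodamine B assay, tested at 10 uM; on this read-out higher numbers stand for more inhibition at the one concentration tested (going by the name of the read-out) and lower numbers for less inhibition:

- compound 1 `CCCCCCCCc1cc(-c2cn([C@H]3C[C@H](O)[C@@H](CO)O3)c(=O)[nH]c2=O)on1` gives 120% in this assay
- compound 2 `CC(=O)OC[C@H]1O[C@@H](n2cc(-c3cc(C)no3)c(=O)[nH]c2=O)C[C@@H]1OC(C)=O` gives 101% in this assay

Among the compounds with values here, compound 2 stands lowest of the two numbers measured so far. Its nearest neighbour is compound 1, whose number lies higher by an amount beyond the usual scatter of this assay. Compound 1 and compound 2 differ from each other in more than one place, so the gap between them cannot be tied to any single change; only the two values themselves are known.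

Compound 3 `CC(=O)OC[C@H]1O[C@@H](n2cc(-c3cc(-c4ccc(C(C)C)cc4)no3)c(=O)[nH]c2=O)C[C@@H]1OC(C)=O` has not yet been measured. It keeps the whole core of compound 2 and changes one group: 4-isopropylphenyl in place of methyl on an aromatic carbon. The group that enters is much larger than the one that leaves and brings one more aromatic ring, while donors, acceptors and charge stay unchanged.

Within the data shown here, no single-point step between measured compounds is available to calibrate this change. Because compound 1 gives 120% with a larger substituent on the same five-membered ring, the step expected from compound 2 to compound 3 is a modest rise, a number 9 percentage points higher from compound 2 to compound 3 (within the scatter), but the uncertainty is wide. Compound 3 is thus estimated at 110%, within 90% to 128%.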

Compound 3, a percentage reported as inhibition, at one concentration (the size of the read-out at that concentration, not a potency): 108%
Estimate against measurement, compound 3: 2 percentage points above; low and high end bracket the measured number.
By their numbers in this assay, from the lowest: compounds 2 and 3 (each within the scatter of the next); then compound 1.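

In this assay, the aromatic carbon next to the ring nitrogen of the five-membered aromatic ring now has its first step that differs in one place: 4-isopropylphenyl in place of methyl gives a number 7 percentage points higher from compound 2 to compound 3 (within the scatter). At this position, therefore, a much larger group bringing one more aromatic ring, with no hydrogen-bond donors or acceptors and no net charge on either side of the exchange, leaves the read-out within its usual scatter, so that this pair does not separate the two groups at the one concentration tested. No measurement bears on the reason for this outcome.

The compounds shown leave open how a carboxylic acid, an amine or a straight octyl chain would read at this same position on the core of compound 2, since compound 1 carries its octyl chain alongside other differences and cannot be compared in one place. Also open is what the two acetate esters contribute, which a pair differing only by free hydroxyl groups in their place would settle, and how any of these compounds would rank at concentrations other than the single one used here.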